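The source may report more compounds than this note shows. Statements on the series, on what has been measured and on what is new or still open speak of the compounds shown alone.

In an assay on CHO cells for displacement of a labelled ligand from prostaglandin D2 receptor 2 (Homo sapiens), read by scintillation counting (a lower number here means a stronger inhibitor, a higher number a weaker inhibitor), compound 1 `Cc1ccc(S(=O)(=O)CCO)cc1C#Cc1cc(Cl)ccc1OCC(=O)O` gives 19 nM, the highest of the three numbers in hand. Compound 3 `CCCS(=O)(=O)c1cccc(C#Cc2c(OCC(=O)O)cccc2-c2ccsc2)c1` gives 18 nM, which lies within the scatter of compound 1, while compound 2 `CCCS(=O)(=O)c1ccc(F)c(C#Cc2cc(Cl)ccc2OCC(=O)O)c1` gives 3.4 nM, a number well below that of compound 1. Compound 4 `Cc1ccc(S(=O)(=O)N2CCCCC2C)cc1C#Cc1cc(Cl)ccc1OCC(=O)O` keeps the core of compound 1 and differs from it only at the sulfonyl sulfur: 2-methylpiperidin-1-yl in place of 2-hydroxyethyl on a sulfonyl sulfur. Among the measured compounds shown here, no measured pair in this set carries the same change, so the size of the step can only be guessed. Compound 4 is expected to show a modest move toward a lower number, close to the edge of the scatter, a step of a 1.9-fold lower number from compound 1 to compound 4 (0.28 log units; within the scatter). The estimated value of compound 4 in this assay is 10 nM, within 3 nM to 40 nM.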

Compound 4, inhibition constant: 1.9 nM
Beside the measured number, compound 4's estimate is 5.3-fold (0.72 log units) above it; measured number below the stated range.
By their numbers in this assay, from the lowest: compounds 4 and 2 (each within the scatter of the next); then compounds 3 and 1 (each within the scatter of the next).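

On the sulfonyl sulfur, the core of compound 1 needs no 2-hydroxyethyl group for a low number in this assay: 2-methylpiperidin-1-yl in its place gives a 10-fold lower number from compound 1 to compound 4 (1.00 log units; beyond the scatter). Among the compounds shown here, the position therefore takes a six-membered non-aromatic ring with no hydrogen-bond donor, which no earlier compound carries there. Nothing at hand explains the size of this step. Going by these compounds, whether the step follows the ring or its methyl group stays open, and piperidin-1-yl or morpholin-4-yl on the same sulfur would separate the two. Also open, on these data alone, is whether the change carries over to the cores of compound 2 and compound 3.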